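Fluoro in place of methyl: compound 1 to compound 3

This account rests on a few compounds, and the source may have more. Where it says the series, first, only, none or still open, it means among the compounds named here.

Compound 1 `Cc1ccc(SCc2ccc(/C=C/C(=O)Nc3ccccc3N)cc2)cc1` stands at the lower end of the two measured compounds in the series. In a functional assay on HCT-116 cells (Homo sapiens) for inhibition, read by CCK-8 assay, with a stated time of 72 h, tested at 2 uM (a higher number here means more inhibition of growth at the concentration tested, a lower number less inhibition of growth), compound 1 gives 6.23%. Compound 2 `Nc1ccccc1NC(=O)c1ccc(CSc2nccc(C(F)(F)F)n2)cc1`, built differently over most of its length, gives 82.7% in this assay, a number that lies beyond the scatter above that of compound 1. For the measured compounds named here, no pair of measured compounds differing in a single place is available, so the effect of a small substituent exchange on this read-out has not yet been observed directly.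

Compound 3 `Nc1ccccc1NC(=O)/C=C/c1ccc(CSc2ccc(F)cc2)cc1` differs from compound 1 by the change (fluoro in place of methyl on an aromatic carbon), sitting on an aromatic carbon of a six-membered aromatic ring of carbon only, para to a large group. The rest of the molecule is kept as in compound 1.

The expected step from compound 1 to compound 3 in this assay is a number 3.8 percentage points higher from compound 1 to compound 3 (within the scatter), small and not beyond the scatter in either direction. Compound 3 is therefore estimated at 10%, with a range from 0% to 30%.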

Compound 3, percent growth inhibition at one concentration: 14.1%
The estimate for compound 3 lay 4.1 percentage points below the measured number; low and high end bracket the measured number.
By their numbers in this assay, from the lowest: compounds 1 and 3 (each within the scatter of the next); then compound 2.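

In this assay, this first pair differing in a single place gives a step of a number 7.9 percentage points higher from compound 1 to compound 3 (within the scatter), so 4-methylphenyl and 4-fluorophenyl cannot be told apart by this read-out. The series thus has its first direct reading of a small substituent exchange: on an aromatic carbon of a six-membered aromatic ring of carbon only, para to a large group, fluoro in place of methyl does not shift percent growth inhibition beyond the usual scatter, though one pair supports this only for this exchange on the core of compound 1. No measurement at hand bears on why the pair reads this way.

Open, on these data alone, is whether a group of another kind at the same place, such as an amine, a carboxylic acid or a longer chain, would give a step beyond the scatter. Also open, as far as these compounds go, is whether fluoro in place of methyl would read the same with the rest of the molecule changed, for example with an oxygen in place of the sulfur of the (4-fluorophenyl)sulfanyl group.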